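Two Measured Compounds and One Awaited Value

The compounds below may be only part of what the source reports. "The series", "measured", "known", "first", "only" and "open" are said of these compounds alone.

Of the compounds shown here, two sharing one core have been tested in a functional assay on HT-29 cells (Homo sapiens) for cytotoxicity, read by MTT assay, with a stated time of 72 h; a higher number here means a weaker inhibitor, a lower number a stronger inhibitor. Compound 1 `CN(C)CCn1cnnc1-c1cc(Oc2ccc(NC(=O)N/N=C/c3cc(C(C)(C)C)cc(C(C)(C)C)c3O)cc2F)ccn1` gives 680 nM in this assay. Compound 2 `CN(C)CCn1cnnc1-c1cc(Oc2ccc(NC(=O)N/N=C/c3ccc(O)c(O)c3)cc2F)ccn1` gives 1890 nM in this assay, the higher of the two numbers, and the gap between compound 2 and compound 1 is wide enough to lie beyond the usual scatter, so compound 2 is the weaker inhibitor of the pair.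

The next compound, compound 3 `Cc1cc(/C=N/NC(=O)Nc2ccc(Oc3ccnc(-c4nncn4CCN(C)C)c3)c(F)c2)cc(C)c1O`, has not yet been measured. It differs from compound 2 in one place: 4-hydroxy-3,5-dimethylphenyl in place of 3,4-dihydroxyphenyl on a carbon with a double bond to nitrogen. The group entering resembles the group that compound 1 carries on the same carbon more closely than the group that leaves, in that it keeps a single hydroxyl flanked by two carbon substituents.

Because compound 1 gives 680 nM while compound 2 gives 1890 nM, the expected step of a 2.1-fold lower number from compound 2 to compound 3 (0.32 log units; beyond the scatter) is a modest move toward a lower number, though it may not clear the scatter. Compound 3 is estimated to give 900 nM in this assay, within a likely range from 300 nM to 2700 nM.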

Compound 3, half-maximal inhibitory concentration: 1220 nM
Estimate against measurement, compound 3: 1.4-fold (0.13 log units) below, within the range that was stated.
By their numbers in this assay, from the lowest: compounds 1, 3 and 2 (each within the scatter of the next, the first and the last beyond it).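

In this assay, putting 4-hydroxy-3,5-dimethylphenyl in place of 3,4-dihydroxyphenyl on the carbon with a double bond to nitrogen gives a 1.5-fold lower number from compound 2 to compound 3 (0.19 log units; within the scatter), so the two compounds cannot be told apart in this test. Within the data shown here, this is the first exchange at this position that can be read on its own, since compound 1 and compound 2 differ in more than one group. It shows that this position accepts a ring bearing methyl groups and a single hydroxyl as readily as the 3,4-dihydroxyphenyl ring, although no measurement at hand explains why.

The compounds shown all keep a hydroxyl on this ring, so it remains open whether a plain phenyl ring, or a ring carrying an amine or a carboxylic acid instead of that hydroxyl, would stay within the scatter of these compounds. They also leave open how the number would respond to a change elsewhere on the shared core, such as a longer chain on the nitrogen-bearing side arm.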